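One Added Methyl, Starting From a Limit

The source may report more compounds than this note shows. Statements on the series, on what has been measured and on what is new or still open speak of the compounds shown alone.

Compound 1 `CC(C)Nc1nc(NCc2ccco2)c2ccccc2n1` is the starting point. In a physicochemical assay for solubility, at pH 2 (a higher number here means a more soluble compound, a lower number a less soluble compound), compound 1 gives >= 30000 nM, which is a limit of the assay and not an exact number. Compound 2 `CC(C)Nc1nc(NC2CCCCC2)c2ccccc2n1` gives >= 30000 nM, which is a limit too.

Compound 3 `Cc1ccc2c(NCc3ccco3)nc(NC(C)C)nc2c1` keeps the core of compound 1 and makes a single change, a methyl in place of hydrogen on an aromatic carbon.

Going by the values given here, only one measured step is available, a step that the two limits leave unreadable from compound 1 to compound 2. It alters a group on a nitrogen rather than an aromatic carbon, so it bears on the new change only indirectly, and it offers no size to carry over. What the data do show is the limit of >= 30000 nM in this assay, at which 2 of the 2 values shown sit. From that standing of compound 1, the expectation in this assay is no step beyond the usual scatter, and another limit is the likeliest result. The expected step is a number no higher from compound 1 to compound 3 (the limit leaves the size open). Compound 3 is estimated at 30000 nM, with an expected range from 15000 nM to 40000 nM.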

Compound 3, solubility: >= 30000 nM
Compound 3 was reported as a limit (the forecaster's own chance of this, stated with the estimate: 75%); the middle value sits exactly at the limit.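

Compound 1 and compound 3 are both reported only as limits in this assay, so the step between them, a methyl in place of hydrogen on an aromatic carbon, cannot be read. The compounds shown leave open how compound 1, compound 2 and compound 3 truly compare, as all of them stand at one value: the limit of >= 30000 nM in this assay, at which 3 of the 3 values shown sit.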